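Removing the methylsulfonyl group from a quinazoline piperidine

The compounds below may be only part of what the source reports. "The series", "measured", "known", "first", "only" and "open" are said of these compounds alone.

Compound 1 `COc1cc2nc(/C=C/c3ccccn3)nc(N3CCC(CCNS(N)(=O)=O)CC3)c2cc1OC` was tested in an assay on cells for inhibition of Ectonucleotide pyrophosphatase/phosphodiesterase family member 1 (Homo sapiens), with a stated time of 60 min (a lower number here means a stronger inhibitor, a higher number a weaker inhibitor), and compound 1 gives 71 nM. Compound 2 `COc1cc2ncnc(N3CCC(CCNS(C)(=O)=O)CC3)c2cc1OC` shares the core of compound 1 but carries no group on the carbon between the two ring nitrogens and ends its side chain in a methanesulfonamide; in this assay compound 2 gives "not determined" (no result reported), so no number is available for compound 2 and it cannot be placed against compound 1.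

Compound 3 `COc1cc2ncnc(N3CCC(CCN)CC3)c2cc1OC` differs from compound 2 by hydrogen in place of methylsulfonyl on an amine nitrogen. Going by the values given here, because compound 2 has no value, the size of the step from compound 2 to compound 3 in this assay cannot be read from these data, and only the single value of compound 1 offers any anchor. A loss of the methylsulfonyl group is expected to leave compound 3 somewhat weaker than compound 1 in this assay, with wide uncertainty. Compound 3 is therefore estimated at 600 nM in this assay, with a plausible range from 60 nM to 6000 nM.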

Compound 3, inhibition constant: 699 nM
Compound 3: the middle estimate sits 1.2-fold (0.07 log units) below what was measured, and the stated range covers the measured number.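

Going by these compounds alone, compound 2 has no number in this assay, so no step from it to compound 3 can be read, and compound 3 differs from compound 1 in more than one place. What the compounds shown leave open is how much the methylsulfonyl group itself contributes in this assay. Nothing given here bears on the value of compound 3.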